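The source may report more compounds than this note shows. Statements on the series, on what has been measured and on what is new or still open speak of the compounds shown alone.

Measured so far:
compound 1 `Cc1ccc2cc(C(C)N(Cc3ccc(F)cc3)Cc3ccc(C(C)C)cc3)c(=O)[nH]c2c1` — > 33000 nM
compound 2 `CCOc1ccc(CN(Cc2ccc(C(C)(C)C)cc2)Cc2cc3cc(C)ccc3[nH]c2=O)cc1` — > 10000 nM

Compound 2 is known only from a toxicity assay on MDCK cells (Canis lupus familiaris) for cytotoxicity, read by crystal violet staining, with a stated time of 48 h; a lower number here means that less compound is tolerated, a higher number that more compound is tolerated. Its value there, > 10000 nM, is a limit of the assay rather than a number; compound 2 thus tolerated the highest concentration tested without reaching half-maximal cytotoxicity. Compound 1 likewise gives only a limit in this assay, > 33000 nM, at a different ceiling. With both values sitting at limits (the limit of > 10000 nM in this assay, at which 1 of the 2 values shown sits, (the limit of > 33000 nM in this assay, at which 1 of the 2 values shown sits)), the two show no ordering between them, only that neither produced a measurable cytotoxic midpoint.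

Compound 3 `Cc1ccc2[nH]c(=O)c(CN(Cc3ccc(C(C)(C)C)cc3)C(C)c3ccc(F)cc3)cc2c1` differs from compound 2 in one place: 1-(4-fluorophenyl)ethyl in place of 4-ethoxybenzyl on an amine nitrogen.

Going by the values given here, no step between two measured compounds is available in this assay, so the effect of this exchange cannot be read from the series. Compound 1 carries the 1-(4-fluorophenyl)ethyl group on the amine nitrogen and also gives only a limit, so no step beyond the scatter is expected from compound 2 to compound 3. For compound 3, the estimated value is 20000 nM (range 8000 nM to 50000 nM), an expected step that the limit leaves unreadable from compound 2 to compound 3, most likely reported again as a limit.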

Compound 3, half-maximal cytotoxic concentration: > 33000 nM
Compound 3: no number, only a limit (the forecaster's own chance of this, stated with the estimate: 75%); at least 1.6-fold (0.21 log units) between middle value and limit.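

In this assay, compound 2 and compound 3 both give only limits of the assay, so no step can be read between compound 2 and compound 3. The compounds shown leave open at what concentration, if any, compound 1, compound 2 or compound 3 reaches half-maximal cytotoxicity, and whether this exchange on the amine nitrogen alters tolerance at all.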